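Pyrazole carboxamide series: methoxy for methyl, second instance

The compounds below may be only part of what the source reports. "The series", "measured", "known", "first", "only" and "open" are said of these compounds alone.

Measured compounds:
compound 1 `COc1cccc(NC(=O)c2cnn(-c3ccc(F)cc3)c2C)c1` gives 3700 nM in a functional assay with Homo sapiens as the target; on this read-out higher numbers stand for weaker inhibition and lower numbers for stronger inhibition
compound 2 `Cc1cccc(NC(=O)c2cnn(-c3ccc(F)cc3)c2C)c1` gives 5700 nM in this assay
compound 3 `Cc1cccc(-n2ncc(C(=O)Nc3ccc(C(F)(F)F)cc3)c2C)c1` gives 2500 nM in this assay

Compounds 1 and 2 share one core and differ in one place: methoxy in place of methyl on an aromatic carbon. The step on this change is a 1.5-fold lower number from compound 2 to compound 1 (0.19 log units; within the scatter), so within this pair the two values are within the usual scatter of each other.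

Compound 3 stands on a different core, carrying the trifluoromethyl group on the amide aryl; the difference between the two cores is not broken down here. Compared with compound 2, compound 3 has a lower number, a gap beyond the scatter; compared with compound 1 the two values are within the scatter.

Compound 4 `COc1cccc(-n2ncc(C(=O)Nc3ccc(C(F)(F)F)cc3)c2C)c1` is not yet measured. It is made from compound 3 by the same change that separates compound 2 from compound 1: methoxy in place of methyl on an aromatic carbon. Resting on compound 2 and compound 1, where the change gave a 1.5-fold lower number from compound 2 to compound 1 (0.19 log units; within the scatter), the step in this assay is expected to be a 1.4-fold lower number from compound 3 to compound 4 (0.14 log units; within the scatter), small and within the scatter. Compound 4 is therefore estimated at 1800 nM, between 800 nM and 3600 nM.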

Compound 4, half-maximal inhibitory concentration: 2500 nM
Beside the measured number, compound 4's estimate is 1.4-fold (0.14 log units) below it; the measured number falls inside the stated range.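

In this assay, methoxy in place of methyl on an aromatic carbon gives no change at the digits printed from compound 3 to compound 4 (within the scatter), and on the core of compound 1 it gives a 1.5-fold lower number from compound 2 to compound 1 (0.19 log units; within the scatter). Set side by side, the two steps do not differ beyond what repeated measurements would allow: the same change on two cores in this assay, a 1.5-fold lower number (0.19 log units; within the scatter) from compound 2 to compound 1 and no change at the digits printed (within the scatter) from compound 3 to compound 4, 1.5-fold (0.19 log units) apart, within the scatter of two such steps This shows that the swap left the read-out within the scatter on both cores, but it does not show that methoxy and methyl differ in effect on either core, and two pairs give no rule for cores outside this set.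

The compounds shown leave open whether a larger change at the same aromatic carbon, such as an ethoxy group, an amine or a carboxylic acid, would move the number beyond the scatter on either core. The two cores differ in more than one place, so which of those differences matters, if any, also stays unresolved here.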